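Swapping Methoxy for Bromo in a Cell Tolerance Test

A few compounds are considered here, and "the series" means these few. Any claim that something is new, unique, unknown or untested is made for them only; others in the source may bear on it.

Compound 1 `Cc1ccc(/N=N/N(C)c2ccccc2)cc1`: 58000 nM
Compound 2 `COc1ccc(/N=N/N2CCCC2)cc1`: 90000 nM
Compound 3 `CN(Cc1ccccc1)/N=N/c1ccccc1`: >= 100000 nM (a limit of the assay)

These three compounds were tested in an ADME assay on Vero cells (Chlorocebus sabaeus) for cytotoxicity, read by crystal violet staining (a lower number here means that less compound is tolerated, a higher number that more compound is tolerated), which shows how much compound the cells can bear. There, compound 2 gives 90000 nM. Its nearest neighbour is compound 1 at 58000 nM, and these two numbers lie within the scatter of each other, so they cannot be ranked. Compound 3 gives >= 100000 nM, which is a limit of the assay and not a number.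

The next compound to be tested is compound 4 `Brc1ccc(/N=N/N2CCCC2)cc1`. It carries bromo in place of methoxy on an aromatic carbon of compound 2: bromo in place of methoxy on an aromatic carbon.

Among the measured compounds shown here, no two measured compounds differ in only one place, so the data offer no direct measure of a change like this one. The expectation rests on the closeness of the measured numbers, with compound 1 at 58000 nM and compound 2 at 90000 nM. Only a small change is therefore expected, no larger than the scatter. The expected step is a 1.5-fold lower number from compound 2 to compound 4 (0.18 log units; within the scatter). For compound 4, the estimated value in this assay is 60000 nM, with an expected range of 25000 nM to 120000 nM.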

Compound 4, half-maximal cytotoxic concentration: >= 100000 nM
Compound 4 was reported as a limit; the forecaster's own chance of this, stated with the estimate: 25%; middle value at least 1.6-fold (0.22 log units) away from the limit.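

In this assay, among the compounds shown here, the swap of methoxy for bromo on an aromatic carbon is the first change that can be read in one place, and it gives an at least 1.1-fold higher number from compound 2 to compound 4 (0.04 log units; that floor lies within the scatter). Compound 4 gives >= 100000 nM, which is a limit of the assay and not a number. At this position, para to a group of 7 heavy atoms, the swap therefore does not lower the amount of compound the cells tolerate, but the true size of any rise stays hidden because the readings stop at a ceiling: the limit of >= 100000 nM in this assay, at which 2 of the 4 values shown sit.

Compound 1 and compound 3 differ from compound 2 in more than one place, so they say nothing about whether this swap would behave the same way on another core. Also open, from the compounds shown here alone, is whether a different group at this same position, such as an amine or a carboxylic acid, would move the number beyond the scatter, and in which direction.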